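The compounds below may be only part of what the source reports. "The series", "measured", "known", "first", "only" and "open" are said of these compounds alone.

Working notes on the series. All values come from an ADME assay on HEK293 cells (Homo sapiens) for cytotoxicity, read by MTT assay, with a stated time of 24 h; a higher number here means a weaker inhibitor, a lower number a stronger inhibitor. Compound 1 `O=C1O/C(=C\Cn2cc(Cc3ccccc3)nn2)C(OCc2ccccc2)=C1OCc1ccccc1` gives 70000 nM in this assay. Compound 3 `COC1=C(OC)C(O)(CCn2cc(-c3ccccc3)nn2)NC1=O` gives 62000 nM in this assay, a number that sits within the usual scatter of the value of compound 1, so nothing separates the two. Compound 2 `CC(C)(C)c1ccc(-c2cn(CCC3(O)NC(=O)C(OCc4ccccc4)=C3OCc3ccccc3)nn2)cc1` returns only a limit in this assay, > 100000 nM. This is the limit of > 100000 nM in this assay, at which 1 of the 3 values shown sits, and it is treated as a limit rather than a number.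

Going by the values given here, no pair of measured compounds differs in a single place, so no measured step speaks to the change that leads to compound 4 `O=C1O/C(=C\Cn2cc(-c3ccccn3)nn2)C(OCc2ccccc2)=C1OCc1ccccc1`. The difference from compound 1 is pyridin-2-yl in place of benzyl on an aromatic carbon. Among the compounds with values here, the shared core of compound 1 is left untouched, and the two numbers measured so far sit close to one another, so in this assay no step beyond the scatter is expected in either direction. The step from compound 1 to compound 4 is expected to come out as a 1.1-fold higher number from compound 1 to compound 4 (0.06 log units; within the scatter). For compound 4 the estimate in this assay is 80000 nM, with a range from 40000 nM to 160000 nM, and with a real chance that only a limit is returned.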

Compound 4, half-maximal inhibitory concentration: > 100000 nM
Compound 4 gave a limit, no number (the forecaster's own chance of this, stated with the estimate: 30%); middle value at least 1.2-fold (0.09 log units) from the limit.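

Pyridin-2-yl in place of benzyl on this aromatic carbon gives an at least 1.4-fold higher number from compound 1 to compound 4 (0.15 log units; that floor lies within the scatter) in this assay, the first step that can be read at this place, and the change brings no lower number. Compound 4 returns a limit and not a number, > 100000 nM. The step therefore has only a floor, no real rise can be claimed from it, and the limit is no longer confined to a single compound: the limit of > 100000 nM in this assay, at which 2 of the 4 values shown sit.

From the compounds shown here alone, the size of the step remains open, as does the question of which part of the change matters, since benzyl and pyridin-2-yl differ both in the ring and in the heavy atoms that make up the group. Going by these compounds, it also remains open whether a carboxylic acid or a primary amine on this aromatic carbon, with the shared core of compound 1 left untouched, would return a number or another limit in this assay.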